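The source may report more compounds than this note shows. Statements on the series, on what has been measured and on what is new or still open speak of the compounds shown alone.

Measured so far:
Compound 1 `COC(=O)[C@H](CCSC)NC(=O)c1ccc(CNCc2c[nH]cn2)cc1-c1ccccc1C`: in a functional assay on NIH3T3 cells (Mus musculus) (on this read-out lower numbers stand for an effect already at smaller amounts and higher numbers for an effect only at larger amounts of compound), compound 1 gives 25 uM.
Compound 2 `CSCC[C@H](NC(=O)c1ccc(CNCc2c[nH]cn2)cc1-c1ccccc1C)C(=O)O`: for compound 2 this assay reports only a limit, > 25 uM.

Compound 1 holds the only number shown; the other value is a limit. Within the data shown here, the one measured step, a number no lower from compound 1 to compound 2 (the limit leaves the size open), concerns the ester and not the amine, and its size cannot be read. Compound 3 `COC(=O)[C@H](CCSC)NC(=O)c1ccc(CN(Cc2c[nH]cn2)Cc2c[nH]cn2)cc1-c1ccccc1C` differs from compound 1 by (1H-imidazol-4-yl)methyl in place of hydrogen on an amine nitrogen. Among the measured compounds shown here, no measured step bears on this change, so for compound 3 a step within the scatter is expected, a 1.3-fold lower number from compound 1 to compound 3 (0.10 log units; within the scatter). Compound 3 is therefore estimated at 20 uM, between 6 uM and 60 uM.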

Compound 3, concentration for half-maximal effect: > 10 uM
Compound 3: only a limit was reported; the forecaster's own chance of this, stated with the estimate: 30%; the middle value does not contradict the limit.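

In this assay, among these compounds, compound 3 gives only a limit, > 10 uM, so no step from compound 1 to compound 3 can be read. The compounds shown leave open whether (1H-imidazol-4-yl)methyl in place of hydrogen on an amine nitrogen changes the number.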